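A few compounds are considered here, and "the series" means these few. Any claim that something is new, unique, unknown or untested is made for them only; others in the source may bear on it.

Measured in an ADME assay on the whole organism (Mus musculus, strain CD-1) for pharmacokinetics, at a dose of 10 mg/kg by the oral route; a lower number here means less compound in the circulation, a higher number more compound in the circulation at the dose given:
- compound 1 `COc1cc([C@](O)(CCN(C)C)[C@@H](c2cc3cc(Br)ccc3nc2OC)c2ccnc(OC)c2OC)cc(OC(C)C)n1`: 5600 ng.h/mL
- compound 2 `CCCOc1cc([C@](O)(CCN(C)C)[C@@H](c2cc3cc(Br)ccc3nc2OC)c2ccnc(OC)c2OC)cc(OC)n1`: 10900 ng.h/mL

Only these two compounds have been measured, and they lie within the scatter of each other, so compound 2 stands level with compound 1 and the two are not ranked. The next compound is compound 3 `COc1cc([C@](O)(CCN(C)C)[C@@H](c2cc3cc(Br)ccc3nc2OC)c2ccnc(OC)c2OC)cc(OC2CCC2)n1`, which differs from compound 2 as follows: cyclobutyl in place of propyl on an oxygen on an aromatic ring. This is cyclobutyl in place of propyl on an oxygen on an aromatic ring, or propoxy to cyclobutyloxy.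

For the measured compounds named here, one measured step bears on this change: a 1.9-fold higher number from compound 1 to compound 2 (0.29 log units; within the scatter). It exchanges propyl and isopropyl on an oxygen on an aromatic ring and stays within the scatter. Going by the values given here, no compound with a ring on that oxygen has been measured, so the cyclobutyl group itself is untested and the range stays wide. On the evidence of this single step, no change beyond the scatter is expected in this assay, and the direction is not firmly indicated.

The expected step is a 1.5-fold lower number from compound 2 to compound 3 (0.16 log units; within the scatter). For compound 3 the estimated value is 7500 ng.h/mL, with an expected range of 3500 ng.h/mL to 15000 ng.h/mL.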

Compound 3, area under the concentration-time curve: 8400 ng.h/mL
Compound 3: the middle estimate sits 1.1-fold (0.05 log units) below what was measured; low and high end bracket the measured number.
By their numbers in this assay, from the lowest: compounds 1, 3 and 2 (each within the scatter of the next).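

A ring on this oxygen now has a result: in this assay, cyclobutyl in place of propyl gives a 1.3-fold lower number from compound 2 to compound 3 (0.11 log units; within the scatter), and cyclobutyl in place of isopropyl gives a 1.5-fold higher number from compound 1 to compound 3 (0.18 log units; within the scatter). Both steps lie within the scatter, so compounds 1, 2 and 3 stand level and are not ranked, and the oxygen on the aromatic ring carries propyl, isopropyl or cyclobutyl with no separation in this read-out across these three compounds. The change from an open chain to a four-membered non-aromatic ring of carbon only therefore has no effect that can be told apart here, and nothing available speaks to why these three groups stand level.

Going by these compounds, it remains open whether any group on this oxygen moves the number in this assay beyond the scatter, for example a longer chain such as hexyl, a larger ring such as cyclohexyl, or a chain ending in an amine or a carboxylic acid. Also open, on these data alone, is whether the level standing of propyl, isopropyl and cyclobutyl holds at other doses or by other routes, since these three values come from a single oral dose in one mouse strain.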